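A few compounds are considered here, and "the series" means these few. Any claim that something is new, unique, unknown or untested is made for them only; others in the source may bear on it.

Three compounds share one core and differ only in the chain on the aromatic nitrogen. In a functional assay on ileum for inhibition of histamine H1 receptor (Cavia porcellus) (on this read-out higher numbers stand for weaker inhibition and lower numbers for stronger inhibition), compound 1 `CN1CCN(c2nc3ccccc3n2CCOc2ccccc2)CC1` gives 6.9 nM, compound 2 `CCCOCCn1c(N2CCN(C)CC2)nc2ccccc21` gives 20 nM, and compound 3 `CCCSCn1c(N2CCN(C)CC2)nc2ccccc21` gives 68 nM. Compound 3 thus stands highest of the three, which here means the weakest inhibition: putting propyl in place of phenyl on an oxygen gave a 2.9-fold higher number from compound 1 to compound 2 (0.46 log units; beyond the scatter), putting propylsulfanyl in place of propoxymethyl gave a 3.4-fold higher number from compound 2 to compound 3 (0.53 log units; beyond the scatter), and a 9.9-fold higher number from compound 1 to compound 3 (0.99 log units; beyond the scatter) spans the whole set.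

Compound 4 `CCCC(C)Cn1c(N2CCN(C)CC2)nc2ccccc21` carries a further change at the same place: 1-methylbutyl in place of propylsulfanyl on a saturated chain carbon bound to an aromatic nitrogen. Within the data shown here, of the measured steps, only the one with propylsulfanyl in place of propoxymethyl touches this chain, and it weakened inhibition. Among the measured compounds shown here, no measured step removes the heteroatom entirely, so the direction rests on thin ground. The expectation is a small weakening or no change beyond the scatter, estimated as a 1.5-fold higher number from compound 3 to compound 4 (0.17 log units; within the scatter) in this assay. Compound 4 is expected to give about 100 nM, within a range from 30 nM to 350 nM.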

Compound 4, half-maximal inhibitory concentration: 500 nM
For compound 4 the middle estimate is 5.0-fold (0.70 log units) below the measured one, and the stated range ends below it.
By their numbers in this assay, from the lowest: compound 1; then compound 2; then compound 3; then compound 4.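

In this assay, replacing propylsulfanyl with 1-methylbutyl gives a 7.4-fold higher number from compound 3 to compound 4 (0.87 log units; beyond the scatter), so losing the sulfur at this position and gaining an all-carbon branched chain costs far more than the small shift that might have been assumed. Compound 4 is the weakest of the set, with a 25-fold higher number from compound 2 to compound 4 (1.40 log units; beyond the scatter) and a 72-fold higher number from compound 1 to compound 4 (1.86 log units; beyond the scatter), and among these four compounds, each chain holding an oxygen or a sulfur gives stronger inhibition than the one chain made only of carbon. Nothing available explains why this change weakens inhibition so much.

From the compounds shown here alone, this single change removes the sulfur, adds the branch and alters the chain's size all at once, so their separate contributions remain unknown. A straight pentyl chain could help to separate the branch from the loss of sulfur, while a chain ending in an amine would test a different kind of atom here.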